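Benzimidazole-piperidine series: hydroxyethylsulfanyl for methylsulfanyl

The source may hold more compounds than are shown below. What is called first, only, known or untested is meant among the compounds shown, and "the series" means these compounds.

Compound 1 `CSc1nc2ccccc2n1C1CCN(CCCC(=O)c2ccc(F)cc2)CC1` and compound 2 `O=C(CCCN1CCC(n2c(SCCO)nc3ccccc32)CC1)c1ccc(F)cc1` share one core; compound 3 `CSc1nc2ccccc2n1C1CCN(CCCC(c2ccc(F)cc2)c2ccc(F)cc2)CC1` and the unmeasured compound 4 `OCCSc1nc2ccccc2n1C1CCN(CCCC(c2ccc(F)cc2)c2ccc(F)cc2)CC1` share another. The difference between the two cores is not broken down here. In a functional assay on the whole organism (strain STD-ddY) for inhibition, with Mus musculus as the target, with a stated time of 5 min (on this read-out lower numbers stand for an effect already at smaller amounts and higher numbers for an effect only at larger amounts of compound), compound 1 gives 6.2 mg/kg, and compound 2 gives 6.9 mg/kg. The change between them, (hydroxymethyl in place of hydrogen on a saturated chain carbon bound to a sulfur), produced a 1.1-fold higher number from compound 1 to compound 2 (0.05 log units; within the scatter), a step that stays within the scatter of repeated measurements. In this assay compound 3 gives 13 mg/kg; its number lies beyond the scatter of compound 1 and within the scatter of compound 2, and no single counted difference is given between compound 3 and compound 1.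

Within the data shown here, compound 4 differs from compound 3 by hydroxymethyl in place of hydrogen on a saturated chain carbon bound to a sulfur, the same change as the one from compound 1 to compound 2, at the same place. Among the compounds here the change appears twice, and its one measured occurrence left the number essentially unchanged. On that basis the step in this assay is expected to be a 1.1-fold higher number from compound 3 to compound 4 (0.03 log units; within the scatter), matching the earlier step in kind and size, because a 1.1-fold higher number from compound 1 to compound 2 (0.05 log units; within the scatter) stayed within the scatter. For compound 4 in this assay the estimate is 14 mg/kg, with the likely range from 7 mg/kg to 28 mg/kg; this rests on a single pair and may not hold for the second core.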

Compound 4, dose for half-maximal effect: 40 mg/kg
Compound 4: the middle estimate sits 2.9-fold (0.46 log units) below what was measured, and the stated range ends below it.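

In this assay, the change from methylsulfanyl to (2-hydroxyethyl)sulfanyl gave a 3.1-fold higher number from compound 3 to compound 4 (0.49 log units; beyond the scatter), so on this core the hydroxymethyl in place of hydrogen is no longer a silent change. The size of the step therefore does not carry from one core to the other in this series, and a step read on the core of compound 1 is a poor guide for the core of compound 3: the same change on two cores in this assay, a 1.1-fold higher number (0.05 log units; within the scatter) from compound 1 to compound 2 and a 3.1-fold higher number (0.49 log units; beyond the scatter) from compound 3 to compound 4, 2.8-fold (0.44 log units) apart, beyond the scatter of two such steps This rests on one pair per core; it shows that the outcome of this change depends on the core for these four compounds, but it does not show which part of the difference between the cores is responsible, nor how any further core would behave.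

The compounds shown leave open whether this dependence on the core is particular to the 2-hydroxyethyl group or also applies to other groups, such as a 2-aminoethyl group, a carboxylic acid on the same chain or a longer 3-hydroxypropyl chain, each compared on both cores. They also leave open what a core carrying only part of the difference between the two cores would give for the same change.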